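A few compounds are considered here, and "the series" means these few. Any claim that something is new, unique, unknown or untested is made for them only; others in the source may bear on it.

Measured compounds in a functional assay on CHO cells for agonist activity at Free fatty acid receptor 1 (Homo sapiens), read by a luciferase reporter; a lower number here means a smaller maximal response, a higher number a larger maximal response:

compound 1 `CC(Cc1ccc(NCc2cccc(Oc3ccccc3)c2)cc1)C(=O)O`, compound 1 gives 70%
compound 2 `Cc1nc(-c2ccc(C(F)(F)F)cc2)sc1CNc1ccc(CCC(N)=O)cc1`, compound 2 gives 88%

Compound 1 has the lower of the two numbers recorded so far; compound 2 sits higher by a margin that lies beyond the usual scatter of this assay. Within the data shown here, the two compounds share no single-point change, so no step between them is counted, and what the pair shows is only that a different shape of the molecule can reach a larger maximal response.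

The next compound, compound 3 `O=C(NO)[C@H]1C[C@@H]1c1ccc(NCc2cccc(Oc3ccccc3)c2)cc1`, keeps the whole of compound 1 apart from one end. The change is 2-(hydroxycarbamoyl)cyclopropyl in place of 2-carboxypropyl on an aromatic carbon, set on an aromatic carbon of a six-membered aromatic ring of carbon only, para to a large group. Among the measured compounds shown here, with no counted step available, the size of the move in this assay cannot be read from the data; the expectation is for no change beyond the scatter, with a broad margin on either side. For compound 3 the estimated maximal response is 65%, in the range 40% to 90%, which corresponds to an expected step of a number 5 percentage points lower from compound 1 to compound 3 (within the scatter).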

Compound 3, largest response reached (reported as percent of maximum), in percent of the reference or control that the assay uses: 90%
Estimate against measurement, compound 3: 25 percentage points below, and the stated range covers the measured number.
By their numbers in this assay, from the lowest: compound 1; then compounds 2 and 3 (each within the scatter of the next).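

In this assay, among these compounds, 2-(hydroxycarbamoyl)cyclopropyl in place of 2-carboxypropyl on the aromatic carbon para to a large group gives a number 20 percentage points higher from compound 1 to compound 3 (beyond the scatter), the first counted step. This position is therefore not fixed to the carboxylic acid end of compound 1: with the rest of that molecule kept, a group with one more heavy atom, a three-membered ring of carbon, and two defined stereocentres raises the maximal response. No measured evidence bears on this step, and the data assign it to no single feature of the exchange.

The exchange alters the chain and the terminal group together, so the compounds shown leave open which of the two carries the step; a 2-carboxycyclopropyl group and an open-chain 2-(hydroxycarbamoyl)propyl group at the same place would separate them. Also open, on these data alone, is the role of the stereocentres, which the opposite arrangement of the 2-(hydroxycarbamoyl)cyclopropyl group would address, and whether a primary amide at the end of the cyclopropyl group would hold the same response.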